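The source may report more compounds than this note shows. Statements on the series, on what has been measured and on what is new or still open speak of the compounds shown alone.

Measured compounds:
compound 1, `CC(=O)Nc1ccc(S(=O)(=O)Nc2cccc(-c3nc(-c4ccc(NC(=O)c5cccnc5)cc4)no3)c2)cc1`, 5200 nM;
compound 2, `CC(=O)Nc1ccc(S(=O)(=O)Nc2cccc(-c3nc(-c4ccc(NC(=O)c5cccnc5)c(Cl)c4)no3)c2)cc1`, 4500 nM.

Both numbers come from a functional assay on MDA-MB-231 cells (Homo sapiens) for antiproliferative activity, read by MTT assay, with a stated time of 72 h; on this read-out lower numbers stand for stronger inhibition and higher numbers for weaker inhibition. Compound 2 has the lowest of the two numbers, but its neighbour compound 1 sits within the scatter of it, so the two cannot be told apart. Compound 3, `CC(=O)Nc1ccc(S(=O)(=O)Nc2cccc(-c3nc(-c4ccc(NC(=O)c5cccnc5)c(C(F)(F)F)c4)no3)c2)cc1`, carries the change (trifluoromethyl in place of chloro on an aromatic carbon). Going by the values given here, the only step that bears on this position is the one from compound 1 to compound 2, a 1.2-fold lower number from compound 1 to compound 2 (0.06 log units; within the scatter), where a chloro entered at the same place and did not move the number beyond the scatter. Among the compounds with values here, nothing among the measured compounds shows what a trifluoromethyl does there. The expectation for compound 3 is therefore a step of about no change at the digits printed from compound 2 to compound 3 (within the scatter) in this assay, that is, none beyond the scatter. Compound 3 is estimated at 4500 nM, with a range from 2000 nM to 10000 nM.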

Compound 3, half-maximal inhibitory concentration: > 10000 nM
Compound 3 gave a limit, no number; the forecaster's own chance of this, stated with the estimate: 5%; at least 2.2-fold (0.34 log units) between middle value and limit.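

In this assay compound 3 gives > 10000 nM, which is a limit of the assay and not a number. The position is therefore not indifferent to what it carries: the earlier chloro step stayed within the scatter, whereas trifluoromethyl in place of chloro gives an at least 2.2-fold higher number from compound 2 to compound 3 (0.34 log units; beyond the scatter). Trifluoromethyl in place of hydrogen gives an at least 1.9-fold higher number from compound 1 to compound 3 (0.28 log units; that floor lies within the scatter), so this second comparison does not settle the matter alone, and the true size of both steps remains unknown: the limit of > 10000 nM in this assay, at which 1 of the 3 values shown sits.

The compounds shown leave open whether a different group at this position, such as a methyl, a methoxy or an amine, would stay level with compound 2 or would also reach the limit. They also leave open whether a single fluorine there would behave like chloro or like trifluoromethyl.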